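Methyl on the aniline ring across two benzothiazole cores

The source may report more compounds than this note shows. Statements on the series, on what has been measured and on what is new or still open speak of the compounds shown alone.

Three compounds are measured in a functional assay on MDA-MB-231 cells (Homo sapiens) for antiproliferative activity, read by sulforhodamine B assay, with a stated time of 48 h; on this read-out lower numbers stand for stronger inhibition and higher numbers for weaker inhibition. Compound 1 `COc1cc(OC)c2sc(-c3ccc(N/C=C\C(=O)c4ccc(OC)c(O)c4)c(C)c3)nc2c1` gives 3100 nM. Compound 2 `COc1cc(OC)c2sc(-c3ccc(N/C=C\C(=O)c4ccc(OC)c(O)c4)cc3)nc2c1` gives 7610 nM, and compound 3 `COc1ccc2nc(-c3ccc(N/C=C\C(=O)c4cc(OC)c(OC)c([N+](=O)[O-])c4)cc3)sc2c1` gives 7610 nM, which is level with compound 2 at the digits shown. The difference between the cores of compound 2 and compound 3 is not broken down here.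

Within the core of compound 2, the change methyl in place of hydrogen on an aromatic carbon produced a 2.5-fold lower number from compound 2 to compound 1 (0.39 log units; beyond the scatter). Compound 4 `COc1ccc2nc(-c3ccc(N/C=C\C(=O)c4cc(OC)c(OC)c([N+](=O)[O-])c4)c(C)c3)sc2c1` carries the same kind of change on the core of compound 3, (methyl in place of hydrogen on an aromatic carbon); the place lines differ in that the methyl now stands meta to a 6-methoxy-1,3-benzothiazol-2-yl group rather than meta to a large group.

Going by the values given here, for compound 4 a step of about a 2.4-fold lower number from compound 3 to compound 4 (0.38 log units; beyond the scatter) in this assay is expected, resting on the step seen from compound 2 to compound 1 and on the single occurrence of this change, so the expectation is held loosely. Compound 4 is estimated at 3200 nM, within 1500 nM to 8000 nM.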

Compound 4, half-maximal inhibitory concentration: 5050 nM
Compound 4: middle estimate off by 1.6-fold (0.20 log units), on the low side; the range from low to high includes it.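

In this assay, going by these compounds alone, methyl in place of hydrogen on an aromatic carbon gives a 1.5-fold lower number from compound 3 to compound 4 (0.18 log units; within the scatter), and the gap between this step and the earlier one stays within what two such steps can show: the same change on two cores in this assay, a 2.5-fold lower number (0.39 log units; beyond the scatter) from compound 2 to compound 1 and a 1.5-fold lower number (0.18 log units; within the scatter) from compound 3 to compound 4, 1.6-fold (0.21 log units) apart, within the scatter of two such steps The two cores are therefore compatible with a shared effect of this change, but only the step on the core of compound 2 lies beyond the scatter, so the core of compound 3 gives no independent confirmation of it. Two pairs in one assay do not establish a general rule for the series or fix the size of the step on any other core.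

The compounds shown leave open whether ethyl or chlorine on the same aromatic carbon would give a step like that of methyl. They also leave open how the change would behave on a core carrying an amine in place of the nitro group of compound 4.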